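Methyl for Fluoro on the Phenyl Ring: Expected Cytotoxicity

The compounds below may be only part of what the source reports. "The series", "measured", "known", "first", "only" and "open" are said of these compounds alone.

Among the measured compounds shown here, compound 2 `O=Cc1c(-c2ccc(F)cc2)nc2sc(Cc3ccc(Cl)cc3)nn12` is the only compound with a measured number in an ADME assay on CCRF-CEM cells (Homo sapiens) for cytotoxicity, with a stated time of 72 h (on this read-out higher numbers stand for weaker inhibition and lower numbers for stronger inhibition), where compound 2 gives 17000 nM. Compound 1 `Fc1ccc(-c2nc3sc(Cc4ccc(Cl)cc4)nn3c2Br)cc1` gives only a limit of the assay, > 250000 nM, in this assay. The step of an at least 14-fold lower number from compound 1 to compound 2 (1.16 log units; beyond the scatter) concerns the bromo-to-formyl exchange on the core and not the phenyl ring. Compound 3 `Cc1ccc(-c2nc3sc(Cc4ccc(Cl)cc4)nn3c2C=O)cc1` differs from compound 2 by methyl in place of fluoro on an aromatic carbon. For the measured compounds named here, no measured step touches that ring, so no change beyond the scatter is expected. The estimate for compound 3 in this assay is 17000 nM, between 6000 nM and 50000 nM, which means an expected step of no change at the digits printed from compound 2 to compound 3 (within the scatter).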

Compound 3, half-maximal inhibitory concentration: 17000 nM
The estimate for compound 3 equals the measured number at the digits printed, within the range that was stated.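

In this assay, among the compounds shown here, the exchange of 4-fluorophenyl for 4-methylphenyl gives no change at the digits printed from compound 2 to compound 3 (within the scatter) and is the first measured step on this ring. The earlier step changed only a group on the shared core, whereas this one shows that methyl in place of fluoro, on the carbon para to a large group, leaves the read-out where it stood. Nothing at hand gives a reason for this flat step.

As far as these compounds go, whether this position would tolerate an amine, a carboxylic acid or a longer chain equally well stays open.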